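Methyl for Methoxy on the Aryl Ring of Compound 3

A few compounds are considered here, and "the series" means these few. Any claim that something is new, unique, unknown or untested is made for them only; others in the source may bear on it.

Compound 3 `COc1ccc(N2CCN(CCNC(=O)c3ccco3)CC2)cc1` gives 14.1 nM in a functional assay for antagonist activity at Adrenergic receptor alpha-1 (Rattus norvegicus) (a lower number here means tighter binding, a higher number weaker binding), the lowest of the three numbers here. Compound 2 `COc1ccc(N2CCN(CCNC(=O)c3cccnc3)CC2)cc1` gives 1620 nM, and compound 1 `COc1ccc(Cl)cc1N1CCN(CCNC(=O)c2cc3ccccc3o2)CC1` gives 2340 nM. Among the compounds with values here, the only step between measured compounds, a 110-fold lower number from compound 2 to compound 3 (2.06 log units; beyond the scatter), alters the group on the carbonyl carbon and leaves the aryl ring untouched. Compound 4 `Cc1ccc(N2CCN(CCNC(=O)c3ccco3)CC2)cc1` differs from compound 3 by methyl in place of methoxy on an aromatic carbon. Within the data shown here, no measured pair tests this change, so the expectation rests on the modest size of the change itself. For compound 4 a step of a 1.8-fold higher number from compound 3 to compound 4 (0.25 log units; within the scatter) is expected, a slight weakening at most. The estimate for compound 4 in this assay is 25 nM, within a range from 8 nM to 80 nM.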

Compound 4, dissociation constant: 339 nM
Compound 4: the middle estimate sits 14-fold (1.13 log units) below what was measured; the measured number lies above the stated range.
By their numbers in this assay, from the lowest: compound 3; then compound 4; then compounds 2 and 1 (each within the scatter of the next).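

In this assay, within the data shown here, the change from 4-methoxyphenyl to 4-methylphenyl gives a 24-fold higher number from compound 3 to compound 4 (1.38 log units; beyond the scatter) and so shows that the group on the aryl ring, para to a large group, counts as well as the group on the carbonyl carbon, the only place a step had touched before. Nothing shown gives a measured reason for this step. From the compounds shown here alone, whether a hydroxy group, an ethoxy group or a chlorine atom here would stay near compound 3 or fall near compound 4 remains open. So does whether the same change would carry over with the pyridin-3-yl group of compound 2.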